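The source may report more compounds than this note shows. Statements on the series, on what has been measured and on what is new or still open speak of the compounds shown alone.

Measured so far in a functional assay on HCT-116 cells (Homo sapiens) for inhibition, read by sulforhodamine B assay, with a stated time of 48 h; a lower number here means a stronger inhibitor, a higher number a weaker inhibitor:
- compound 1 `COc1ccc(C(c2ccc(OC(C)CN(C)C)cc2)c2cccc3ccccc23)c(OC)c1OC` gives 8410 nM
- compound 2 `CCOC(=O)CO/N=C(/c1ccc(OC)c(OC)c1OC)c1cccc2ccccc12` gives 3360 nM

Compound 1 has the higher of these two numbers, which makes it the weaker inhibitor, and the gap to compound 2 lies beyond the scatter. Compound 3 `COc1ccc(C(c2ccc(O)cc2)c2cccc3ccccc23)c(OC)c1OC` is not yet measured. It differs from compound 1 in one place hydrogen in place of 1-((dimethylamino)methyl)ethyl on an oxygen on an aromatic ring with hydrogen in place of 1-((dimethylamino)methyl)ethyl on an oxygen on an aromatic ring. Going by the values given here, no measured pair shows this change, so the guess is loose. The expected step of a 1.4-fold higher number from compound 1 to compound 3 (0.15 log units; within the scatter) is small, towards a weaker number, and not expected to pass the scatter. Compound 3 is estimated at 12000 nM with 3000 nM to 45000 nM as its expected range.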

Compound 3, half-maximal inhibitory concentration: 16000 nM
Compound 3: the middle estimate sits 1.3-fold (0.12 log units) below what was measured, and the stated range covers the measured number.
By their numbers in this assay, from the lowest: compound 2; then compounds 1 and 3 (each within the scatter of the next).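

Going by these compounds alone, compound 1 and compound 3 form the only pair here that differs in one place, so they give the first direct look at this oxygen on an aromatic ring. In this assay, swapping 1-((dimethylamino)methyl)ethoxy for hydroxy gives a 1.9-fold higher number from compound 1 to compound 3 (0.28 log units; within the scatter), so even removing this whole chain does not move the number past the scatter. No available evidence explains this result. Going by these compounds, whether a methyl or a longer chain ending in a carboxylic acid on this oxygen would shift the number remains open. So does whether the same change would behave alike on a different core.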